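The source may hold more compounds than are shown below. What is called first, only, known or untested is meant among the compounds shown, and "the series" means these compounds.

Measured so far in an assay on CHO-K1 cells for activation of DNA damage-inducible transcript 3 protein (Homo sapiens), read by a luciferase reporter; a lower number here means that less compound is needed, a higher number that more compound is needed for the effect:
compound 1, `O=C(Nc1ccc(S(=O)(=O)N2CCC(F)CC2)cc1)c1ccc([N+](=O)[O-])o1`, gives 600 nM
compound 2, `O=C(Nc1ccc(S(=O)(=O)N2CCC(Cl)CC2)cc1)c1ccc([N+](=O)[O-])o1`, gives 800 nM

Among the compounds with values here, compound 2 has the higher of these two numbers, but its only neighbour is compound 1, and the gap a 1.3-fold higher number from compound 1 to compound 2 (0.12 log units; within the scatter) is within the scatter, so the two compounds cannot be told apart in this assay. Compound 3, `CC1CCN(S(=O)(=O)c2ccc(NC(=O)c3ccc([N+](=O)[O-])o3)cc2)CC1`, differs from compound 2 by methyl in place of chloro on a saturated ring carbon. Within the data shown here, the one step that bears on this place, from fluoro to chloro, was a 1.3-fold higher number from compound 1 to compound 2 (0.12 log units; within the scatter) and stayed within the scatter. A step of about no change at the digits printed from compound 2 to compound 3 (within the scatter) is therefore expected, with no direction beyond the scatter. Compound 3 is estimated at 800 nM, in a range from 350 nM to 1800 nM.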

Compound 3, concentration for half-maximal activity: 700 nM
Beside the measured number, compound 3's estimate is 1.1-fold (0.06 log units) above it; the range from low to high includes it.
By their numbers in this assay, from the lowest: compounds 1, 3 and 2 (each within the scatter of the next).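

In this assay the step of a 1.1-fold lower number from compound 2 to compound 3 (0.06 log units; within the scatter) and the step of a 1.2-fold higher number from compound 1 to compound 3 (0.07 log units; within the scatter) both lie within the scatter, for methyl in place of chloro and methyl in place of fluoro on this saturated ring carbon. A carbon group now stands alongside the two halogens at this place, and the three compounds cannot be told apart. No evidence is available to explain this result.

Each group shown here has only one heavy atom. As far as these compounds go, whether an amine, a carboxylic acid or a longer chain at this ring carbon would give a similar number remains open.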